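The compounds below may be only part of what the source reports. "The series", "measured", "known", "first", "only" and "open" are said of these compounds alone.

For the measured compounds named here, compound 1 `COc1ccc(Cn2c(CCc3ccccc3)nnc2[C@H](NC(=O)C(C)(C)N)c2c[nH]c3ccccc23)cc1` gives the lowest of the three numbers measured so far in an in vitro assay on LLC-PK1 cells for displacement of a labelled ligand from growth hormone secretagogue receptor type 1 (Homo sapiens); on this read-out lower numbers stand for stronger inhibition and higher numbers for weaker inhibition: compound 1 gives 11 nM. Compound 2 `COc1ccc(Cn2c(CCc3ccccc3)nnc2[C@H](NC(=O)C(C)(C)N)c2c[nH]c3ccccc23)c(OC)c1` gives 60 nM, and compound 3 `COc1ccc(Cn2c(CCc3ccccc3)nnc2[C@H](NC(=O)c2ccncc2)c2c[nH]c3ccccc23)c(OC)c1` gives 58 nM. The change from compound 1 to compound 4 `COc1ccc(Cn2c(CCc3ccccc3)nnc2[C@H](NC(=O)Cc2ccncc2)c2c[nH]c3ccccc23)cc1` is (pyridin-4-yl)methyl in place of 1-amino-1-methylethyl on a carbonyl carbon. The measured step that bears on this is a 1.0-fold lower number from compound 2 to compound 3 (0.01 log units; within the scatter), which also replaced 1-amino-1-methylethyl on a carbonyl carbon with a pyridine ring and stayed within the scatter. The step of a 5.5-fold higher number from compound 1 to compound 2 (0.74 log units; beyond the scatter) concerns a methoxy group elsewhere and says nothing about this exchange. Compound 4 is therefore expected to show a 1.4-fold higher number from compound 1 to compound 4 (0.13 log units; within the scatter), within the scatter. Compound 4 is estimated at 15 nM, with a range from 5 nM to 45 nM.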

Compound 4, half-maximal inhibitory concentration: 270 nM
Estimate against measurement, compound 4: 18-fold (1.26 log units) below, outside the stated range (above it).
By their numbers in this assay, from the lowest: compound 1; then compounds 3 and 2 (each within the scatter of the next); then compound 4.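

At this carbonyl carbon, the earlier exchange of 1-amino-1-methylethyl for pyridin-4-yl gave a 1.0-fold lower number from compound 2 to compound 3 (0.01 log units; within the scatter) and so suggested tolerance, but (pyridin-4-yl)methyl gives a 25-fold higher number from compound 1 to compound 4 (1.39 log units; beyond the scatter) in a large step. Replacing 1-amino-1-methylethyl here can therefore cost much in one setting and nothing measurable in another. No measurement shown explains the large step. The two steps differ in both the entering group and the second methoxy, so the compounds shown cannot separate these two changes. Going by these compounds, how an aminomethyl group would behave at this carbonyl carbon also stays open.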